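Moving the chlorine on the outer phenyl ring

This account rests on a few compounds, and the source may have more. Where it says the series, first, only, none or still open, it means among the compounds named here.

These compounds share one core carrying two aryl groups and a chain that ends in a second ring amine. Compound 1 `Cc1ccc(-c2nnc(N3CCN(C(=O)CN4CCN(c5ccc(Cl)cc5)CC4)CC3)nc2-c2ccc(C)cc2)cc1` gives 567000 nM in an ADME assay on NIH3T3 cells (Mus musculus) for cytotoxicity, read by MTT assay, with a stated time of 24 h; a higher number here means a weaker inhibitor, a lower number a stronger inhibitor. Compound 2 `COc1ccccc1N1CCN(CC(=O)N2CCN(c3nnc(-c4ccc(Cl)cc4)c(-c4ccc(Cl)cc4)n3)CC2)CC1` gives 405000 nM in this assay. Compound 3 `O=C(CN1CCN(c2ccccc2Cl)CC1)N1CCN(c2nnc(-c3ccc(Cl)cc3)c(-c3ccc(Cl)cc3)n2)CC1` reaches only a limit of the assay, > 803000 nM, so for compound 3 there is no number, only a limit. For the measured compounds named here, the one measured step, an at least 1.9-fold higher number from compound 2 to compound 3 (0.29 log units; that floor lies within the scatter), is itself capped by that limit, (the limit of > 803000 nM in this assay, at which 1 of the 3 values shown sits), and its floor lies within the scatter. Compound 4 `O=C(CN1CCN(c2cccc(Cl)c2)CC1)N1CCN(c2nnc(-c3ccc(Cl)cc3)c(-c3ccc(Cl)cc3)n2)CC1` differs from compound 3 by 3-chlorophenyl in place of 2-chlorophenyl on an amine nitrogen in a ring. Going by the values given here, no measured step moves a chlorine to another place on the same phenyl, so that comparison has no precedent here, and the single measured step offers only a small floor. The step of an at least 1.1-fold lower number from compound 3 to compound 4 (0.05 log units; that floor lies within the scatter) is therefore expected to be small, with no direction beyond the scatter. Compound 4 is estimated at 700000 nM, between 350000 nM and 1500000 nM in this assay.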

Compound 4, half-maximal inhibitory concentration: > 803000 nM
Compound 4: only a limit was reported (the forecaster's own chance of this, stated with the estimate: 50%); middle value at least 1.1-fold (0.05 log units) from the limit.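

In this assay compound 4 gives > 803000 nM, which is a limit of the assay and not a number. The step between compound 3 and compound 4 therefore cannot be read, so moving the chlorine around the outer phenyl ring shows no measurable change, and the limit now caps more of the series: the limit of > 803000 nM in this assay, at which 2 of the 4 values shown sit.

For the compounds shown here, the only readable step for the new compound is an at least 1.9-fold higher number from compound 2 to compound 4 (0.29 log units; that floor lies within the scatter), which adds nothing beyond the floor already seen in an at least 1.9-fold higher number from compound 2 to compound 3 (0.29 log units; that floor lies within the scatter).

On these data alone, it remains open whether a different group at this place, such as a pyridine ring or a phenyl ring bearing a carboxylic acid, would give a value clear of the limit. Until then, 2-chlorophenyl and 3-chlorophenyl cannot be ranked against each other.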